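This account rests on a few compounds, and the source may have more. Where it says the series, first, only, none or still open, it means among the compounds named here.

Compound 1 `N#C/C(=C1/SCC(=O)N1c1ccccc1)n1c(-c2ccco2)nc2ccccc21`: 55900 nM
Compound 2 `NNC(=O)CSc1nnc(Cn2c(-c3ccco3)nc3ccccc32)s1`: 21400 nM

Both values come from a functional assay on MCF7 cells (Homo sapiens) for cytotoxicity, read by sulforhodamine B assay, with a stated time of 48 h; on this read-out higher numbers stand for weaker inhibition and lower numbers for stronger inhibition. Compound 2 has the lower number of the two, and the gap to compound 1 lies beyond the usual scatter. Compound 3 `CCOC(=O)CSc1nnc(Cn2c(-c3ccco3)nc3ccccc32)s1` keeps the rest of compound 2 and changes one group: ethoxy in place of aminoamino on a carbonyl carbon. Going by the values given here, no measured pair shows what this change does, so the expectation is cautious. The estimated step of a 1.1-fold lower number from compound 2 to compound 3 (0.03 log units; within the scatter) is expected to stay within the scatter, with no clear direction. For compound 3 the expected value is 20000 nM, with an estimated range of 6500 nM to 60000 nM.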

Compound 3, half-maximal inhibitory concentration: 28500 nM
Estimate against measurement, compound 3: 1.4-fold (0.15 log units) below; the measured number falls inside the stated range.
By their numbers in this assay, from the lowest: compounds 2, 3 and 1 (each within the scatter of the next, the first and the last beyond it).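

In this assay, ethoxy in place of aminoamino on this carbonyl carbon gives a 1.3-fold higher number from compound 2 to compound 3 (0.12 log units; within the scatter), so the two compounds cannot be told apart. The hydrogen-bond donors of aminoamino leave with this change, yet the step stays within the scatter, so in this pair the read-out does not depend clearly on which of the two groups is present. No available evidence accounts for this result. Still open, on these data alone, is whether a carboxylic acid, an amine or a longer ester chain on this carbonyl carbon would move the number beyond the scatter. As far as these compounds go, the same change on a different core also remains untested here.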